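The compounds below may be only part of what the source reports. "The series", "measured", "known", "first", "only" and "open" are said of these compounds alone.

- compound 1 `COc1cc(-c2nc(-c3ccccc3)[nH]c2-c2ccnc(NCCCNS(=O)(=O)c3ccc(Cl)cc3)n2)ccc1F` gives 83100 nM
- compound 2 `COc1cc(-c2nc(-c3ccccc3)[nH]c2-c2ccnc(NCCCNS(=O)(=O)c3ccc(C(F)(F)F)cc3)n2)ccc1F` gives 75200 nM
- compound 3 `COc1cc(-c2nc(-c3ccccc3)[nH]c2-c2ccnc(NCCCNS(=O)(=O)c3cccc(F)c3)n2)ccc1F` gives 900 nM

In a functional assay on LOX IMVI cells (Homo sapiens) for cytotoxicity, read by MTT assay, with a stated time of 24 h (a higher number here means a weaker inhibitor, a lower number a stronger inhibitor), compound 3 has the lowest number of the three, and both of its steps to the others lie beyond the scatter. Compound 4 `COc1cc(-c2nc(-c3ccccc3)[nH]c2-c2ccnc(NCCCNS(=O)(=O)c3ccc(C)cc3)n2)ccc1F` carries 4-methylphenyl in place of 3-fluorophenyl on a sulfonyl sulfur. Two measured steps remove or install that same 3-fluorophenyl group: a 92-fold lower number from compound 1 to compound 3 (1.97 log units; beyond the scatter) and an 84-fold lower number from compound 2 to compound 3 (1.92 log units; beyond the scatter) are both large. Between the 4-chlorophenyl and 4-(trifluoromethyl)phenyl compounds, a 1.1-fold lower number from compound 1 to compound 2 (0.04 log units; within the scatter) stays within the scatter. Among the compounds with values here, no measured compound carries 4-methylphenyl, so the size of the change is uncertain, but a clear rise in the number is expected. The expected step is a 22-fold higher number from compound 3 to compound 4 (1.35 log units; beyond the scatter) in this direction. Compound 4 is estimated at 20000 nM with an estimated range from 3000 nM to 85000 nM.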

Compound 4, half-maximal inhibitory concentration: 2590 nM
Beside the measured number, compound 4's estimate is 7.7-fold (0.89 log units) above it; measured number outside the range, below it.
By their numbers in this assay, from the lowest: compound 3; then compound 4; then compounds 2 and 1 (each within the scatter of the next).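

In this assay, the step of a 2.9-fold higher number from compound 3 to compound 4 (0.46 log units; beyond the scatter) is only modest, so leaving 3-fluorophenyl on the sulfonyl sulfur does not by itself bring the large loss seen with compounds 1 and 2. The group on the aromatic carbon matters: methyl in place of trifluoromethyl gives a 29-fold lower number from compound 2 to compound 4 (1.46 log units; beyond the scatter), and methyl in place of chloro gives a 32-fold lower number from compound 1 to compound 4 (1.51 log units; beyond the scatter). Compound 4 therefore shows that a 4-substituted phenyl can stay close to compound 3, while compounds 1 and 2 go against any rule that such groups are weak.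

Nothing shown here explains why methyl parts so far from chloro and trifluoromethyl. Where a 4-methoxyphenyl or an unsubstituted phenyl on the sulfonyl sulfur would fall remains open.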